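The source may hold more compounds than are shown below. What is called first, only, known or untested is meant among the compounds shown, and "the series" means these compounds.

Three measured compounds share one core and differ only in the group carried on an aromatic carbon. Compound 1 `OC1CCCN(c2nc(-c3ccccn3)nc3c2CN(Cc2ccccc2)CC3)C1` gives 62.9% in an assay on FRT cells with Cystic fibrosis transmembrane conductance regulator variant F508del (Homo sapiens) as the target, read by fluorescence, with a stated time of 25 min; a higher number here means a larger maximal response, a lower number a smaller maximal response. Compound 2 `NC(=O)C1CCN(c2nc(-c3ccccn3)nc3c2CN(Cc2ccccc2)CC3)CC1` gives 56.6% in this assay, and compound 3 `NC(=O)CN1CCN(c2nc(-c3ccccn3)nc3c2CN(Cc2ccccc2)CC3)CC1` gives 57.9% in this assay. On these numbers compound 3 stands second highest of the three, with compound 2 nearest and compound 1 furthest, though all three lie within the scatter of one another. The steps of a number 6.3 percentage points lower from compound 1 to compound 2 (within the scatter), a number 5 percentage points lower from compound 1 to compound 3 (within the scatter) and a number 1.3 percentage points higher from compound 2 to compound 3 (within the scatter) are each within the scatter.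

Compound 4 `CN1CCN(CCCNc2nc(-c3ccccn3)nc3c2CN(Cc2ccccc2)CC3)CC1` arises from compound 3 by the change ((3-(4-methylpiperazin-1-yl)propyl)amino in place of 4-(carbamoylmethyl)piperazin-1-yl on an aromatic carbon). Going by the values given here, no measured step replaces a ring attached directly to the aromatic carbon with a (3-(4-methylpiperazin-1-yl)propyl)amino group, so none bears directly on this change; the three measured steps show only that exchanging one six-membered non-aromatic ring with two hetero atoms for another barely moves the largest response reached. One therefore expects a step of a number 1.9 percentage points lower from compound 3 to compound 4 (within the scatter) with no direction beyond the scatter, but with more uncertainty than the measured steps carry. One estimates for compound 4 a value of 56%, expected to fall between 35% and 75%.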

Compound 4, largest response reached (Emax), in percent of the reference or control that the assay uses: 53.4%
For compound 4 the middle estimate is 2.6 percentage points above the measured one; measured number inside the range.
By their numbers in this assay, from the lowest: compounds 4, 2, 3 and 1 (each within the scatter of the next).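

The three earlier compounds all carry a ring attached directly to this aromatic carbon, whereas compound 4 places the (3-(4-methylpiperazin-1-yl)propyl)amino group there, and in this assay this larger change of attachment gives a number 4.5 percentage points lower from compound 3 to compound 4 (within the scatter). Set against the other two compounds, the same group gives a number 3.2 percentage points lower from compound 2 to compound 4 (within the scatter) and a number 9.5 percentage points lower from compound 1 to compound 4 (within the scatter), so the position accepts an amino-linked chain as well as a directly attached ring, with all four compounds within the scatter of one another. Nothing at hand explains this flat response to the change.

The compounds shown leave open whether a shorter or longer chain ahead of the 4-methylpiperazin-1-yl ring, an open-chain dimethylamino group at the end of the propyl chain, or a carboxylic acid in place of the carbamoyl group would move the largest response reached beyond the scatter. From the compounds shown here alone, the pyridin-2-yl group is the same in all four compounds, so it also remains open how these groups at this position would behave with another group, such as a phenyl ring, in its place.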